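This account rests on a few compounds, and the source may have more. Where it says the series, first, only, none or still open, it means among the compounds named here.

The measured compounds:
compound 1 `CCCc1cn(C(c2ccccc2)c2ccccc2)nn1` gives 11000 nM in an assay on isolated protein for inhibition of Aromatase (Homo sapiens), read by fluorescence and colorimetric assay, with a stated time of 30 min; on this read-out lower numbers stand for stronger inhibition and higher numbers for weaker inhibition
compound 2 `CCCCCCc1cn(C(c2ccccc2)c2ccccc2)nn1` gives 14800 nM in this assay
compound 3 `CCCCCCCCCCc1cn(C(c2ccccc2)c2ccccc2)nn1` gives 13500 nM in this assay

Compound 2 stands level with its two neighbours in this assay: the step of a 1.3-fold higher number from compound 1 to compound 2 (0.13 log units; within the scatter) and the step of a 1.1-fold lower number from compound 2 to compound 3 (0.04 log units; within the scatter) are both within the scatter, as is the step of a 1.2-fold higher number from compound 1 to compound 3 (0.09 log units; within the scatter). Lengthening the chain on the shared core, from propyl through hexyl to decyl, therefore leaves the number where it was.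

Compound 4 `c1ccc(C(c2ccccc2)n2cc(C3CCCCC3)nn2)cc1` carries a change of another kind: cyclohexyl in place of hexyl on an aromatic carbon. The carbon count is unchanged, but the chain is closed into a ring. Among the measured compounds shown here, no measured pair shows a ring in place of a chain, so the only steps that bear on it are the chain-length steps just named, and all of them are within the scatter. On this basis no step beyond the scatter is expected in this assay, in either direction, for the step of a 1.1-fold lower number from compound 2 to compound 4 (0.06 log units; within the scatter). Compound 4 is estimated at 13000 nM in this assay, with a range from 6000 nM to 28000 nM that allows for the untested nature of the ring change.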

Compound 4, half-maximal inhibitory concentration: 13700 nM
Compound 4: the middle estimate sits 1.1-fold (0.02 log units) below what was measured; the measured number falls inside the stated range.
By their numbers in this assay, from the lowest: compounds 1, 3, 4 and 2 (each within the scatter of the next).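

In this assay, closing the chain into a ring on an aromatic carbon of the five-membered aromatic ring with 3 nitrogen, cyclohexyl in place of hexyl, gives a 1.1-fold lower number from compound 2 to compound 4 (0.03 log units; within the scatter) and stays within the scatter, and cyclohexyl in place of propyl gives a 1.2-fold higher number from compound 1 to compound 4 (0.10 log units; within the scatter) and also stays within the scatter. The earlier compounds shown here compared open chains only, whereas this pair shows that the number at this place also stays level when six carbons in an open chain are replaced by six carbons in a ring, so all four compounds now stand level whatever the shape or length of the carbon group. No measurement shown here offers an explanation for this lack of change.

On these data alone, every group seen at this place is built of carbon and hydrogen only, so it remains open whether an amine, a hydroxyl or a carboxylic acid there would move the number beyond the scatter. Also open, as far as these compounds go, is whether a phenyl ring or a smaller ring such as cyclopropyl would stand level with these compounds, and whether the same holds when the rest of the shared core is changed.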